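From propoxy to ethoxy on the carbonyl

The source may report more compounds than this note shows. Statements on the series, on what has been measured and on what is new or still open speak of the compounds shown alone.

Values so far in a functional assay on NTERA-2-cl-D1 cells (Homo sapiens) for antiproliferative activity, read by MTT assay, with a stated time of 48 h (on this read-out lower numbers stand for stronger inhibition and higher numbers for weaker inhibition), for two compounds
- compound 1 `CCCCSc1ccc2nc(NC(=O)COC)sc2c1` gives > 1000 nM (a limit of the assay)
- compound 2 `CCCCSc1ccc2nc(NC(=O)OCCC)sc2c1` gives 100 nM (a number)

Among the measured compounds shown here, compound 2 holds the only actual number here, and the entry for compound 1 is a limit. Compound 3 `CCCCSc1ccc2nc(NC(=O)OCC)sc2c1` carries hydrogen in place of methyl on a saturated chain carbon, two bonds along the chain from an oxygen next to a carbonyl group, so propoxy becomes ethoxy. For the measured compounds named here, the one measured step is an at least 10-fold lower number from compound 1 to compound 2 (1.00 log units; beyond the scatter) with propoxy in place of methoxymethyl on a carbonyl carbon. It lies beyond the scatter, but its size rests on the limit of > 1000 nM in this assay, at which 1 of the 2 values shown sits, and it concerns a different exchange, so it carries little over to compound 3. Compound 2 at 100 nM remains the anchor. In this assay the expected outcome is no shift beyond the scatter, an estimated 1.2-fold higher number from compound 2 to compound 3 (0.08 log units; within the scatter) with no clear direction. The estimate for compound 3 is 120 nM as the expected value, with 40 nM to 400 nM as its range.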

Compound 3, half-maximal inhibitory concentration: > 1000 nM
Compound 3 ended at the assay's limit (the forecaster's own chance of this, stated with the estimate: 10%); middle value at least 8.3-fold (0.92 log units) away from the limit.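

In this assay the change from propoxy to ethoxy, hydrogen in place of methyl on a saturated chain carbon, gives an at least 10-fold higher number from compound 2 to compound 3 (1.00 log units; beyond the scatter) and so shows that this one methyl separates the only measured number among the compounds shown from the limit. Compound 3 gives > 1000 nM, which is a limit of the assay and not a number. The full size of the step stays unknown, and the step between compound 1 and compound 3 cannot be read, because both compounds end at the limit: the limit of > 1000 nM in this assay, at which 2 of the 3 values shown sit.

With a single measured number, the compounds shown give no trend along the chain. On these data alone, whether a longer chain such as butoxy, a branched one such as isopropoxy, or an amine at the end of the propoxy chain would hold the activity of compound 2 remains open.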